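Moving the Fluorine on the Benzyl Group of Compound 2

A few compounds are considered here, and "the series" means these few. Any claim that something is new, unique, unknown or untested is made for them only; others in the source may bear on it.

Measured compounds:
compound 1, `N#Cc1cccc(COc2ccc(-c3cc(CN4CCN(c5ccc(C(F)(F)F)cn5)CC4)no3)cc2)c1`: 1300 nM
compound 2, `N#Cc1cccc(COc2ccc(-c3cc(CN4CCN(Cc5ccccc5F)CC4)no3)cc2)c1`: 2300 nM

In a functional assay on Mahlavu cells (Homo sapiens) for antiproliferative activity, read by sulforhodamine B assay, with a stated time of 72 h (a higher number here means a weaker inhibitor, a lower number a stronger inhibitor), compound 2 gives 2300 nM, and compound 1 gives 1300 nM. For the measured compounds named here, the only measured step, a 1.8-fold higher number from compound 1 to compound 2 (0.25 log units; within the scatter), lies within the scatter, so on these numbers the two compounds cannot be told apart. Compound 3, `N#Cc1cccc(COc2ccc(-c3cc(CN4CCN(Cc5cccc(F)c5)CC4)no3)cc2)c1`, differs from compound 2 in one place: 3-fluorophenyl in place of 2-fluorophenyl on a saturated chain carbon bound to an amine nitrogen in a ring. The two compounds have the same atoms, joined differently. Going by the values given here, nothing measured bears directly on this change: the one step recorded exchanges a whole group on the ring amine nitrogen, and no pair has been measured in which the same atoms of a benzyl group are merely joined differently. With no guidance from the data, no step beyond the scatter is expected in this assay in either direction. Compound 3 is therefore estimated at 2300 nM, with a range from 900 nM to 6000 nM. This corresponds to an expected step of no change at the digits printed from compound 2 to compound 3 (within the scatter).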

Compound 3, half-maximal inhibitory concentration: 2600 nM
Beside the measured number, compound 3's estimate is 1.1-fold (0.05 log units) below it, within the range that was stated.
By their numbers in this assay, from the lowest: compounds 1, 2 and 3 (each within the scatter of the next).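

Moving the fluorine, with 3-fluorophenyl in place of 2-fluorophenyl, gives a 1.1-fold higher number from compound 2 to compound 3 (0.05 log units; within the scatter) in this assay and so cannot be told from no change: on this saturated chain carbon, these two arrangements of the same atoms read alike. The larger exchange of 5-(trifluoromethyl)pyridin-2-yl for 3-fluorobenzyl gives a 2.0-fold higher number from compound 1 to compound 3 (0.30 log units; within the scatter) and also stays within the scatter, so the three groups shown on this amine nitrogen cannot be separated by these numbers. No supporting measurement is available to account for this result.

Going by these compounds, it remains open whether a plain benzyl group, without fluorine, would read any differently. A methoxy group or a carboxylic acid on the benzyl ring might also give a step beyond the scatter, which none of these compounds shows.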